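Growing the ether group from isopropyl to cyclopentyl

The source may hold more compounds than are shown below. What is called first, only, known or untested is meant among the compounds shown, and "the series" means these compounds.

Going by the values given here, compound 2, `CC(C)Oc1cccc(-c2csc(NC(=O)c3ccc([N+](=O)[O-])o3)n2)c1`, gives 0.27 ug/mL in a physicochemical assay for solubility, read by HPLC, with a stated time of 30 min (a higher number here means a more soluble compound, a lower number a less soluble compound), the lowest of the two numbers measured so far. Compound 1, `CCOc1cccc(-c2csc(NC(=O)c3ccc([N+](=O)[O-])o3)n2)c1`, gives 0.34 ug/mL in this assay; the step of a 1.3-fold lower number from compound 1 to compound 2 (0.10 log units; within the scatter) is within the scatter, so the two compounds cannot be told apart on solubility. Compound 3, `O=C(Nc1nc(-c2cccc(OC3CCCC3)c2)cs1)c1ccc([N+](=O)[O-])o1`, differs from compound 2 by cyclopentyl in place of isopropyl on an oxygen on an aromatic ring. Among the compounds with values here, the only measured step that bears on this change is the earlier growth of the group on that same oxygen, a 1.3-fold lower number from compound 1 to compound 2 (0.10 log units; within the scatter), which was too small to count. Both known values are already very low, and the new group is larger again, so a small drop or no change beyond the scatter is expected. Compound 3 is estimated to give 0.18 ug/mL, within a range from 0.08 ug/mL to 0.4 ug/mL. This estimate means an expected step of a 1.5-fold lower number from compound 2 to compound 3 (0.18 log units; within the scatter).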

Compound 3, solubility: 0.027 ug/mL
The estimate for compound 3 lay 6.7-fold (0.82 log units) above the measured number; the measured number lies below the stated range.
By their numbers in this assay, from the lowest: compound 3; then compounds 2 and 1 (each within the scatter of the next).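

The group on this oxygen is not a silent position in this assay: cyclopentyl in place of isopropyl gives a 10-fold lower number from compound 2 to compound 3 (1.00 log units; beyond the scatter), although the earlier change from ethyl to isopropyl stayed within the scatter. Cyclopentyl in place of ethyl gives a 13-fold lower number from compound 1 to compound 3 (1.10 log units; beyond the scatter), so the response to growing this ether is not gradual across these three compounds, and a clear fall appears only with the ring. Nothing available here accounts for the size of this fall.

Going by these compounds, it remains open whether the ring itself or simply the larger group goes with the lower number; an open pentyl chain on the same oxygen would separate the two. On these data alone, it also remains open whether an ether carrying an amine or a hydroxyl group would raise the number.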